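Swapping one aromatic ring for another on a shared core

The source may report more compounds than this note shows. Statements on the series, on what has been measured and on what is new or still open speak of the compounds shown alone.

The measure throughout is an assay on CHO cells for displacement of a labelled ligand from adenosine receptor A1 (Homo sapiens), read by scintillation counting, tested at 10 uM; on this read-out higher numbers stand for more inhibition at the one concentration tested (going by the name of the read-out) and lower numbers for less inhibition. Compound 1 `CC(C)(C)Cc1c(-c2cccc(F)c2F)sc(N)c1C(=O)c1ccc(Cl)cc1` gives 1% in this assay, and compound 2 `Cc1ccc(C(=O)c2c(CC(C)(C)C)csc2N)cc1` gives 1%, so compound 1 stands level with compound 2 at the digits shown, the two values falling within the usual scatter of each other. Compound 3 `COc1ccc(-c2sc(N)c(C(=O)c3ccc(Cl)cc3)c2CC(C)(C)C)cc1` has not yet been measured. It differs from compound 1 in a single place: 4-methoxyphenyl in place of 2,3-difluorophenyl on an aromatic carbon. Among the measured compounds shown here, no step between measured compounds covers a change of this kind, so nothing yet shows how far exchanging one six-membered aromatic ring of carbon only for another moves the read-out on this core. With both measured compounds sitting at the bottom of the scale, the expected step is a number 1 percentage points higher from compound 1 to compound 3 (within the scatter), which means no movement beyond the scatter. Compound 3 is therefore estimated at 2% in this assay, with an expected range from -8% to 12%.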

Compound 3, a percentage reported as inhibition, at one concentration (the size of the read-out at that concentration, not a potency): 1%
Estimate against measurement, compound 3: 1 percentage points above; low and high end bracket the measured number.
By their numbers in this assay, from the lowest: compounds 1, 2 and 3 (each within the scatter of the next).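

On the core of compound 1, the position next to the ring sulfur now has its first direct test: in this assay, 4-methoxyphenyl in place of 2,3-difluorophenyl gives no change at the digits printed from compound 1 to compound 3 (within the scatter). The two rings have the same heavy-atom count, but the entering group carries a hydrogen-bond acceptor and the leaving group does not, and that difference leaves no mark on this read-out. All the values sit at the bottom of the scale, so this exchange shows no gain in inhibition at the one concentration tested, and no measurement here explains why.

Going by these compounds, what remains open is whether any other group at this position would lift the read-out clear of the scatter, such as an amine or a carboxylic acid on the aromatic ring. A flat result between two compounds this low also cannot show how much this position would matter on a compound with clear inhibition.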